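From sec-butyl to isobutyl in compound 3

This account rests on a few compounds, and the source may have more. Where it says the series, first, only, none or still open, it means among the compounds named here.

In a functional assay on HeLa cells (Homo sapiens) for antiproliferative activity, read by MTT assay, with a stated time of 48 h (a lower number here means a stronger inhibitor, a higher number a weaker inhibitor), compound 2 (`CC[C@@H](C)[C@H](NC(=O)c1ccc(Oc2nc3ccccc3nc2NC(C)(C)C)cc1)C(=O)OC`) gives 31900 nM and compound 1 (`COC(=O)[C@H](CC(C)C)NC(=O)c1ccc(Oc2nc3ccccc3nc2C)cc1`) gives 21600 nM. These two values lie within the scatter of each other, so neither compound can be ranked above the other.

Compound 3 (`COC(=O)[C@H](CC(C)C)NC(=O)c1ccc(Oc2nc3ccccc3nc2NC(C)(C)C)cc1`) has not yet been measured. It has the same atoms as compound 2, joined differently: isobutyl in place of sec-butyl on a saturated chain carbon bound to an amide-type nitrogen and a carbonyl carbon, with isobutyl in place of sec-butyl on a saturated chain carbon bound to an amide-type nitrogen and a carbonyl carbon.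

For the measured compounds named here, no measured step shows what this swap does. Going by the values given here, compound 2 at 31900 nM and compound 1 at 21600 nM are the only guides, so no shift beyond the scatter is expected in this assay. The estimated step, a 1.1-fold lower number from compound 2 to compound 3 (0.06 log units; within the scatter), is small and its direction uncertain. Compound 3 is expected to give 28000 nM, within an estimated range of 14000 nM to 55000 nM.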

Compound 3, half-maximal inhibitory concentration: > 50000 nM
Compound 3: no number, only a limit; the forecaster's own chance of this, stated with the estimate: 8%; middle value at least 1.7-fold (0.25 log units) away from the limit.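

In this assay compound 3 gives > 50000 nM, which is a limit of the assay and not a number: the limit of > 50000 nM in this assay, at which 1 of the 3 values shown sits.

With the isobutyl chain held the same, (tert-butyl)amino in place of methyl on an aromatic carbon gives an at least 2.3-fold higher number from compound 1 to compound 3 (0.36 log units; beyond the scatter), so this change weakens the compound by more than the scatter. Isobutyl in place of sec-butyl gives an at least 1.5-fold higher number from compound 2 to compound 3 (0.19 log units; that floor lies within the scatter), and since that floor lies within the scatter, the two chains cannot yet be told apart at this position.

From the compounds shown here alone, the true value of compound 3 stays unknown, so the full size of both steps stays open. Also open, going by these compounds, is what a simple amine on that aromatic carbon, or a carboxylic acid in place of the methyl ester, would do in this assay.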